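From cyclobutyl to 2-methylprop-1-en-1-yl: an expected half-life

The compounds below may be only part of what the source reports. "The series", "measured", "known", "first", "only" and "open" are said of these compounds alone.

Of the compounds shown here, two sharing one core have been measured so far. In an in vitro ADME assay on microsomes from liver (Homo sapiens) for metabolic stability, tested at 5 uM (a lower number here means that the compound disappears faster, a higher number that the compound lasts longer), compound 1 (`CC(C)CCn1nc(-c2cccs2)c(O)c(C2=NS(=O)(=O)c3cc(N(C)S(C)(=O)=O)ccc3N2)c1=O`) gives 0.467 h and compound 2 (`CC(C)CCn1nc(C2CCC2)c(O)c(C2=NS(=O)(=O)c3cc(NS(C)(=O)=O)ccc3N2)c1=O`) gives 0.317 h as its half-life. These two values lie within the scatter of each other, so compound 2 stands level with compound 1 on these numbers. Among the measured compounds shown here, the two compounds differ in more than one place, and no measured step isolates a single change.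

Compound 3 (`CC(C)=Cc1nn(CCC(C)C)c(=O)c(C2=NS(=O)(=O)c3cc(NS(C)(=O)=O)ccc3N2)c1O`) is the next to be tested. It carries 2-methylprop-1-en-1-yl in place of the cyclobutyl of compound 2 on an aromatic carbon (2-methylprop-1-en-1-yl in place of cyclobutyl on an aromatic carbon). The two groups hold the same count of heavy atoms, but nothing measured shows what this exchange does in this assay here. The half-life of compound 2 at 0.317 h is therefore the best starting point. A slight lean downward is expected, with no change beyond the scatter, and the estimated step is a 1.1-fold lower number from compound 2 to compound 3 (0.05 log units; within the scatter) in size. For compound 3 the expected half-life is 0.28 h (estimated range 0.13 h to 0.6 h).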

Compound 3, half-life: 0.55 h
Beside the measured number, compound 3's estimate is 2.0-fold (0.29 log units) below it, within the range that was stated.
By their numbers in this assay, from the lowest: compounds 2, 1 and 3 (each within the scatter of the next).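

In this assay, placing 2-methylprop-1-en-1-yl in place of cyclobutyl on this aromatic carbon, next to the ring nitrogen and ortho to a hydroxy group, gives a 1.7-fold higher number from compound 2 to compound 3 (0.24 log units; within the scatter), and this is the first step shown that isolates a single change. It shows that at this position, the four-membered carbon ring can give way to an open group with no ring, one double bond outside aromatic rings and the same count of heavy atoms, without a shift beyond the scatter. No measurement shown here bears on what lies behind this step.

Among the compounds shown here, with only one single-change step at this position, it remains open whether the double bond or the loss of the ring matters more, and the saturated 2-methylpropyl chain would separate the two. As far as these compounds go, it also remains open how the half-life would respond to a group of another kind on this aromatic carbon, such as an amine, a carboxylic acid or a longer chain.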